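Tertiary alkyl swap on the cyanoguanidine nitrogen

The compounds below may be only part of what the source reports. "The series", "measured", "known", "first", "only" and "open" are said of these compounds alone.

Measured compounds:
compound 1 `CC(C)CC/N=C(\NC#N)Nc1cc(C(F)(F)F)cc(C(F)(F)F)c1`, 5600 nM
compound 2 `CC(C)/N=C(\NC#N)Nc1cc(C(F)(F)F)cc(C(F)(F)F)c1`, 61000 nM
compound 3 `C[C@@H](/N=C(\NC#N)Nc1cc(C(F)(F)F)cc(C(F)(F)F)c1)C(C)(C)C`, 20300 nM

In a functional assay (aorta) with Rattus norvegicus as the target (on this read-out higher numbers stand for weaker inhibition and lower numbers for stronger inhibition), compound 1 holds the lowest number of the three. The steps from it run one way: an 11-fold higher number from compound 1 to compound 2 (1.04 log units; beyond the scatter) and a 3.6-fold higher number from compound 1 to compound 3 (0.56 log units; beyond the scatter). Compound 4 `CCC(C)(C)/N=C(\NC#N)Nc1cc(C(F)(F)F)cc(C(F)(F)F)c1` differs from compound 1 by 1,1-dimethylpropyl in place of isopentyl on a double-bonded nitrogen. Both steps away from compound 1 replace isopentyl with a group attached through a branched carbon, and both weaken inhibition, so the same is expected here, with compound 3 the closer guide because a 3.0-fold lower number from compound 2 to compound 3 (0.48 log units; beyond the scatter) shows the larger branched group recovering part of the loss. For compound 4 the expected step is a 3.2-fold higher number from compound 1 to compound 4 (0.51 log units; beyond the scatter). Compound 4 is thus estimated at 18000 nM, within 6000 nM to 55000 nM.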

Compound 4, half-maximal inhibitory concentration: 900 nM
Estimate against measurement, compound 4: 20-fold (1.30 log units) above, outside the stated range (below it).
By their numbers in this assay, from the lowest: compound 4; then compound 1; then compound 3; then compound 2.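

In this assay, branching at the carbon bound to the double-bonded nitrogen does not by itself weaken inhibition: with the same atoms joined differently, 1,1-dimethylpropyl gives a 6.2-fold lower number from compound 1 to compound 4 (0.79 log units; beyond the scatter), whereas isopropyl and 1,2,2-trimethylpropyl both gave higher numbers than isopentyl. The gap to those branched groups is wider, with a 23-fold lower number from compound 3 to compound 4 (1.35 log units; beyond the scatter) and a 68-fold lower number from compound 2 to compound 4 (1.83 log units; beyond the scatter), so the outcome here follows the particular alkyl group, not branching as such. Nothing available bears on why this is so. As far as these compounds go, whether tert-butyl or 1,1-dimethylbutyl on this nitrogen would keep the lower number remains open.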